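A few compounds are considered here, and "the series" means these few. Any claim that something is new, unique, unknown or untested is made for them only; others in the source may bear on it.

Measured compounds in a functional assay on QGY7701 cells (Homo sapiens) for cytotoxicity, read by MTT assay, with a stated time of 24 h; on this read-out higher numbers stand for weaker inhibition and lower numbers for stronger inhibition:

Compound 1, `C=CC1=C(C(=O)NC(C)(C)C)C(c2ccc(OC)cc2)OC1`: in this assay compound 1 gives only a limit, > 100000 nM.
Compound 2, `C=CC1=C(C(=O)NCc2ccc(C)cc2)C(c2ccc(OC)cc2)OC1`: in this assay compound 2 gives 43100 nM.
Compound 3, `C=CC1=C(C(=O)Nc2ccc(C)cc2)C(c2ccc(OC)cc2)OC1`: in this assay compound 3 gives only a limit, > 100000 nM.

Compound 3 thus sits at the limit of this assay, as noted in the limit of > 100000 nM in this assay, at which 2 of the 3 values shown sit; its standing against compound 1 is not readable, since a step that the two limits leave unreadable from compound 1 to compound 3. Against compound 2 the step is readable: an at least 2.3-fold higher number from compound 2 to compound 3 (0.36 log units; beyond the scatter), so the 4-methylphenyl amide stands weaker than the 4-methylbenzyl amide by at least a modest margin.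

Compound 4, `C=CC1=C(C(=O)NCc2ccccc2)C(c2ccc(OC)cc2)OC1`, is the next step: benzyl in place of 4-methylphenyl on an amide-type nitrogen. This change undoes the part of the step from compound 2 to compound 3 that inserts a methylene between the amide nitrogen and the aromatic ring, while dropping the methyl on that ring. The step that bears on it is an at least 2.3-fold higher number from compound 2 to compound 3 (0.36 log units; beyond the scatter), read in the opposite direction: the benzyl-type amide of compound 2 gives 43100 nM. A lower number than the limit of compound 3 is therefore expected for compound 4, in the region of compound 2, so that an at least 1.6-fold lower number from compound 3 to compound 4 (0.22 log units; that floor lies within the scatter) is expected. The estimate for compound 4 is 60000 nM, with a range from 25000 nM to 150000 nM.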

Compound 4, half-maximal inhibitory concentration: > 100000 nM
Compound 4: only a limit was reported; the forecaster's own chance of this, stated with the estimate: 35%; middle value at least 1.6-fold (0.22 log units) from the limit.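

In this assay, within the data shown here, hydrogen in place of methyl on an aromatic carbon of the benzyl-type amide gives an at least 2.3-fold higher number from compound 2 to compound 4 (0.36 log units; beyond the scatter), and this is the only readable step for compound 4. The earlier compounds left open whether the benzyl-type amide alone was enough to bring a value under the limit, since compound 2 differed from compound 3 in both the methylene and the placing of the methyl; among the compounds shown, the unsubstituted benzyl amide does not do so, and a measured number appears only with the 4-methylbenzyl group of compound 2. Compound 1, compound 3 and compound 4 all give only limits, so the steps among them cannot be read, and no order can be stated for the tert-butyl, 4-methylphenyl and benzyl amides: the limit of > 100000 nM in this assay, at which 3 of the 4 values shown sit.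

Open, as far as these compounds go, is whether the gain is tied to methyl itself or would also appear with another group on that ring, such as the 4-chlorobenzyl, 4-methoxybenzyl or 4-ethylbenzyl amide. Also open, from the compounds shown here alone, is how a longer chain from the amide nitrogen to the ring, as in the 2-phenylethyl amide, would read.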